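The source may hold more compounds than are shown below. What is called first, only, known or untested is meant among the compounds shown, and "the series" means these compounds.

Measured so far:
compound 1 `O=C(C1CCN(c2ncccn2)CC1)N1N=CC[C@H]1c1ccccc1`: 4.7
compound 2 `CC(C)C(=O)N1N=CCC1c1ccccc1`: 4.4

Both numbers come from a physicochemical assay for lipophilicity, read by HPLC, measured as chromatographic lipophilicity, at pH 7.4; on this read-out lower numbers stand for lower lipophilicity and higher numbers for higher lipophilicity. Of the two, compound 1 carries the larger, but the gap to compound 2 lies within the scatter, so the pair cannot be told apart. Compound 3 `O=C(C1CCN(c2ccccn2)CC1)N1N=CC[C@H]1c1ccccc1` is still to be run in this assay. It differs from compound 1 in one place: pyridin-2-yl in place of pyrimidin-2-yl on an amine nitrogen in a ring. For the measured compounds named here, no measured pair carries this change. For compound 3 a rise beyond the scatter is expected in this assay, around a number 0.70 log units higher from compound 1 to compound 3 (beyond the scatter), which gives an estimate of 5.4 with a range from 4.9 to 5.9.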

Compound 3, distribution coefficient: 5.1
Estimate against measurement, compound 3: 0.30 log units above; measured number inside the range.
By their numbers in this assay, from the lowest: compounds 2 and 1 (each within the scatter of the next); then compound 3.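

In this assay, for the compounds shown here, pyridin-2-yl in place of pyrimidin-2-yl gives a number 0.40 log units higher from compound 1 to compound 3 (beyond the scatter) and is the only single-place step so far. The group on this amine nitrogen in a ring therefore moves the read-out beyond the scatter, with the heavy-atom count unchanged and one ring nitrogen and one hydrogen-bond acceptor fewer. Nothing at hand bears on the cause of this step.

Open, on these data alone, is how other groups on this nitrogen, such as phenyl or cyclohexyl, would read. Also open, as far as these compounds go, is whether the step holds on any other core.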